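This account rests on a few compounds, and the source may have more. Where it says the series, first, only, none or still open, it means among the compounds named here.

Measured so far in a functional assay on MCF7 cells (Homo sapiens) for antiproliferative activity, read by sulforhodamine B assay, with a stated time of 48 h; on this read-out lower numbers stand for stronger inhibition and higher numbers for weaker inhibition:
- Compound 1 `C[C@H]1N=C2C[C@H]3C[C@H](C3(C)C)[C@@]2(C)OC1=O`: compound 1 gives 38000 nM
- Compound 2 `CC1(C)[C@@H]2CC3=N[C@@H](CCC(=O)O)C(=O)O[C@@]3(C)[C@H]1C2`: compound 2 gives 38000 nM
- Compound 3 `CC1(C)N=C2C[C@H]3C[C@H](C3(C)C)[C@@]2(C)OC1=O`: compound 3 gives 162000 nM

Compound 2 stands level with compound 1 at the digits shown, and the two together give the lowest numbers of the three in this assay. Compound 3 sits furthest from compound 2, with a higher number that lies beyond the usual scatter of the measurement.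

Compound 4 `C[C@@H]1N=C2C[C@@H]3C[C@@H](C3(C)C)[C@]2(C)OC1=O` has not yet been measured. Compared with compound 2, the change is hydrogen in place of carboxymethyl on a saturated chain carbon bound to a saturated ring carbon. Compound 4 therefore carries the same arrangement of groups as compound 1, which gives 38000 nM in this assay, and compound 1 is level with compound 2.

Since compound 1 and compound 2 are level, the step from compound 2 to compound 4 is expected to be small, a 1.2-fold higher number from compound 2 to compound 4 (0.07 log units; within the scatter), with no change beyond the scatter in either direction. Compound 4 is thus estimated at 45000 nM in this assay, within a range of 15000 nM to 150000 nM.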

Compound 4, half-maximal inhibitory concentration: 154000 nM
Compound 4: the middle estimate sits 3.4-fold (0.53 log units) below what was measured; the whole stated range lies below it.
By their numbers in this assay, from the lowest: compounds 1 and 2 (each within the scatter of the next); then compounds 4 and 3 (each within the scatter of the next).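

Configuration matters in this series: with the atoms and bonds unchanged, the mirror image gives a 4.1-fold higher number from compound 1 to compound 4 (0.61 log units; beyond the scatter), so carrying the same groups as compound 1 does not secure the same number. Hydrogen in place of carboxymethyl on a saturated chain carbon bound to a saturated ring carbon comes with a 4.1-fold higher number from compound 2 to compound 4 (0.61 log units; beyond the scatter), a step of the same printed size. That step cannot be credited to the group alone, and the gap within the mirror-image pair is due to configuration, as the structures show: the fact that compounds 1 and 4 differ only in the configuration as drawn

The compounds shown leave open whether the mirror image of compound 2 would also give a higher number than compound 2. They also leave open how an amine or an ester at the end of the chain would behave in either configuration.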